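The source may hold more compounds than are shown below. What is called first, only, known or untested is meant among the compounds shown, and "the series" means these compounds.

Measured compounds:
Compound 1 `O=C(CSc1snnc1-c1ccccc1)Nc1ccccc1F`: in an ADME assay on MT4 cells (Homo sapiens) for cytotoxicity (a higher number here means that more compound is tolerated, a lower number that less compound is tolerated), compound 1 gives > 361000 nM, which is a limit of the assay rather than a number.
Compound 2 `COc1ccc(-c2nnsc2SCC(=O)Nc2ccc(C)cc2Br)cc1`: in this assay compound 2 gives 249000 nM.
Compound 3 `CCOC(=O)c1ccc(NC(=O)CSc2snnc2-c2ccc(OC)cc2)c(Br)c1`: in this assay compound 3 gives > 245000 nM, again a limit of the assay and not a number.

Among the compounds with values here, compound 2 therefore stands as the only real number in this small set; the two other values are limits. Within the data shown here, the one measured step that joins compound 2 to another compound, a step that the limit leaves unreadable from compound 2 to compound 3, has no readable size because compound 3 sits at the limit of > 245000 nM in this assay, at which 1 of the 3 values shown sits.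

Compound 4 `COc1ccc(-c2nnsc2SCC(=O)Nc2ccccc2F)cc1` differs from compound 2 by 2-fluorophenyl in place of 2-bromo-4-methylphenyl on an amide-type nitrogen. Compound 1 carries the same 2-fluorophenyl group on the amide nitrogen and rests at the limit of > 361000 nM in this assay, at which 1 of the 3 values shown sits. Among the measured compounds shown here, no measured step gives a readable size for this kind of change, so the expectation rests on compound 1 and compound 2 alone.

Compound 4 is expected to give 300000 nM, with a range from 150000 nM to 450000 nM. The expected step of a 1.2-fold higher number from compound 2 to compound 4 (0.08 log units; within the scatter) from compound 2 to compound 4 is estimated to be small, at most slightly upward, and a limit rather than a number is thought fairly likely.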

Compound 4, half-maximal cytotoxic concentration: > 332000 nM
Compound 4: only a limit was reported (the forecaster's own chance of this, stated with the estimate: 55%); at least 1.1-fold (0.04 log units) between middle value and limit.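

Within the data shown here, putting 2-fluorophenyl in place of 2-bromo-4-methylphenyl on the amide-type nitrogen gives, in this assay, the first step at this position with a readable floor (an at least 1.3-fold higher number from compound 2 to compound 4 (0.12 log units; that floor lies within the scatter)). Compound 4 gives a limit of the assay and not a number (> 332000 nM). With 2-fluorophenyl on the amide-type nitrogen, compound 1 and compound 4 both end at limits, so the methoxy change between them cannot be read, and neither can the other step that ends at a limit.

Going by these compounds, how far the true values of compound 1, compound 3 and compound 4 lie from their limits stays open, so the groups on the amide-type nitrogen cannot yet be ranked. Also open, on these data alone, is whether an amine or a carboxylic acid in place of 2-fluorophenyl on the amide-type nitrogen would bring the value into a readable range.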